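From a cyclobutyl amide to a difluorocyclohexyl amide

A few compounds are considered here, and "the series" means these few. Any claim that something is new, unique, unknown or untested is made for them only; others in the source may bear on it.

Three compounds share one core and differ only in the group on the carbonyl carbon. Compound 1 `O=C(N1CCC(F)CC1)N1CC(c2nc(-c3cccc(Cl)c3)no2)C1` carries a 4-fluoropiperidin-1-yl there, and in an assay on HEK293 cells for positive allosteric modulation of metabotropic glutamate receptor 5 (Homo sapiens), read by FLIPR (on this read-out higher numbers stand for an effect only at larger amounts of compound and lower numbers for an effect already at smaller amounts), compound 1 gives 990 nM. Compound 2 `O=C(N1CCCCC1)N1CC(c2nc(-c3cccc(Cl)c3)no2)C1` carries a plain piperidin-1-yl, and in this assay compound 2 gives 370 nM, a change of a 2.7-fold lower number from compound 1 to compound 2 (0.43 log units; beyond the scatter). Compound 3 `O=C(C1CCC1)N1CC(c2nc(-c3cccc(Cl)c3)no2)C1` carries a cyclobutyl; for compound 3 this assay reports only a limit, > 10000 nM, which is the limit of > 10000 nM in this assay, at which 1 of the 3 values shown sits. Compound 3 therefore stands lowest of the three, with an at least 10-fold higher number from compound 1 to compound 3 (1.00 log units; beyond the scatter) and an at least 27-fold higher number from compound 2 to compound 3 (1.43 log units; beyond the scatter).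

The next step, from compound 3 to compound 4 `O=C(C1CCC(F)(F)CC1)N1CC(c2nc(-c3cccc(Cl)c3)no2)C1`, is 4,4-difluorocyclohexyl in place of cyclobutyl on a carbonyl carbon. Within the data shown here, no measured step exchanges one carbon-attached ring for another. The two measured steps into compound 3 both swap a nitrogen-attached six-membered ring for the small carbon ring, and both lose strongly. Going by these compounds, compound 4 brings back a six-membered ring, though attached through carbon, so some return toward compound 1 and compound 2 is expected, while a ring on carbon remains untested. The expected step is an at least 3.3-fold lower number from compound 3 to compound 4 (0.52 log units; beyond the scatter), toward a lower number. Compound 4 is estimated at 3000 nM, between 700 nM and 10000 nM.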

Compound 4, half-maximal effective concentration: 180 nM
The estimate for compound 4 lay 17-fold (1.22 log units) above the measured number, and the stated range ends above it.
By their numbers in this assay, from the lowest: compound 4; then compound 2; then compound 1. At a limit, above all of these: compound 3.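

In this assay, a ring attached through carbon on this carbonyl carbon is not in itself a loss, since 4,4-difluorocyclohexyl in place of cyclobutyl gives an at least 55-fold lower number from compound 3 to compound 4 (1.74 log units; beyond the scatter) and so recovers everything that cyclobutyl appeared to cost. The compound 3 end of that step is a limit and not a number, so the size of the step is only a minimum: the limit of > 10000 nM in this assay, at which 1 of the 4 values shown sits. Until now the lower numbers belonged only to rings attached through nitrogen, yet the carbon-attached ring of compound 4 goes beyond both of them, with a 2.1-fold lower number from compound 2 to compound 4 (0.31 log units; beyond the scatter) and with a 5.5-fold lower number from compound 1 to compound 4 (0.74 log units; beyond the scatter), so among these four compounds an amide-type nitrogen at this point is not needed for a low number.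

The step from cyclobutyl enlarges the ring and adds two fluorine atoms together, and with no plain cyclohexyl among the compounds shown, the share of each in the change remains open. Also open, going by these compounds, is how 4,4-difluoropiperidin-1-yl would read on the same carbonyl carbon, which would set the two fluorine atoms against the atom that joins the ring to the carbonyl.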